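The source may report more compounds than this note shows. Statements on the series, on what has been measured and on what is new or still open speak of the compounds shown alone.

Compound 1 `N#Cc1ccc(NCc2cncn2Cc2ccc(-c3ccccc3)cc2)cc1-c1ccccc1` was examined in a toxicity assay on NIH3T3 cells (Mus musculus) for cytotoxicity, read by resazurin assay; on this read-out higher numbers stand for an effect only at larger amounts of compound and lower numbers for an effect already at smaller amounts. In this assay compound 1 gives > 1000 nM, which is a limit of the assay and not a number. That is the only thing known about where compound 1 stands, as the limit of > 1000 nM in this assay, at which 1 of the 2 values shown sits, shows. Compound 2 `COC(=O)c1ccc(NCc2cncn2Cc2ccccc2Br)cc1-c1ccccc1` gives 10000 nM in this assay. Going by the values given here, the two measured compounds differ in more than one place, so no measured step between them is available, and the two values simply show what each compound does on its own.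

Compound 3 `c1ccc(-c2ccc(Cn3cncc3CNc3ccc(N4CCCCC4)c(-c4ccccc4)c3)cc2)cc1` remains to be measured in this assay. It differs from compound 1 by piperidin-1-yl in place of cyano on an aromatic carbon. Among the compounds with values here, with no measured step to lean on, the expected step that the limit leaves unreadable from compound 1 to compound 3 is a small one, not beyond the usual scatter, in either direction. In this assay compound 3 is therefore expected to give about 6000 nM, with a range from 1500 nM to 25000 nM.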

Compound 3, half-maximal effective concentration: > 1000 nM
Compound 3: a limit, no number; the forecaster's own chance of this, stated with the estimate: 40%; the middle value lies beyond the limit too.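

No step from compound 1 to compound 3 can be read, because each of the two gives a limit of the assay and not a number: the limit of > 1000 nM in this assay, at which 2 of the 3 values shown sit.

The compounds shown leave open where compound 1 and compound 3 truly lie, and whether piperidin-1-yl in place of cyano shifts the read-out at all.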